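The compounds below may be only part of what the source reports. "The series", "measured", "known", "first", "only" and "open" are said of these compounds alone.

Of the compounds shown here, three have been measured in an assay on CHO cells for displacement of a labelled ligand from melanin-concentrating hormone receptor 1 (Homo sapiens), read by scintillation counting, with a stated time of 1 h; a lower number here means a stronger inhibitor, a higher number a weaker inhibitor. Compound 1 `Cc1c(C2CC2)nc2ccc(NC(=O)COc3ccc(OC(F)(F)F)cc3)cn12` gives 3 nM in this assay. Compound 2 `Cc1oc2ccc(NC(=O)COc3ccc(OC(F)(F)F)cc3)cc2c1C` returns only a limit of the assay in this assay, namely > 1000 nM, so it yields no number. Compound 3 `Cc1c(C2CC2)nc2ccc(-n3ccc(OCc4ccc(F)cc4)cc3=O)cn12` gives 47 nM in this assay. Of the two real numbers this is the higher one. The gap separating compound 1 and compound 3 lies beyond the scatter of repeated measurements of this kind.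

Compound 4 `Cc1c(C2CC2)nc2ccc(-n3ccc(OCc4ccc(C(C)C)cc4)cc3=O)cn12` differs from compound 3 in one place: isopropyl in place of fluoro on an aromatic carbon. For the measured compounds named here, no pair of measured compounds differs by this change alone, so there is no measured step to lean on. A change of this kind is expected to move the number only moderately, with no firm direction, and the expected step is a 1.3-fold higher number from compound 3 to compound 4 (0.11 log units; within the scatter). Compound 4 is therefore estimated at 60 nM in this assay, with a range running from 15 nM to 250 nM.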

Compound 4, half-maximal inhibitory concentration: 410 nM
Beside the measured number, compound 4's estimate is 6.8-fold (0.83 log units) below it; the whole stated range lies below it.
By their numbers in this assay, from the lowest: compound 1; then compound 3; then compound 4. At a limit, above all of these: compound 2.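

For the compounds shown here, replacing 4-fluorobenzyl with 4-isopropylbenzyl gives the first measured step at this position: in this assay the change brings an 8.7-fold higher number from compound 3 to compound 4 (0.94 log units; beyond the scatter), so the number responds clearly to what sits on this aromatic carbon. Here, the group with three carbons in place of a single fluorine gives the weaker inhibitor, but one pair of compounds cannot establish a trend. Nothing in the data shown accounts for the size of this step.

As far as these compounds go, how a methoxy group, an amine or a carboxylic acid on this aromatic carbon would read in this assay remains open. From the compounds shown here alone, it is also open whether a plain hydrogen there would fall closer to compound 3 or to compound 4, and whether a longer chain would weaken inhibition further.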